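The source may hold more compounds than are shown below. What is called first, only, known or untested is meant among the compounds shown, and "the series" means these compounds.

Measured so far in a functional assay on HCT-116 cells (Homo sapiens) for antiproliferative activity, with a stated time of 72 h; on this read-out lower numbers stand for stronger inhibition and higher numbers for weaker inhibition:
- compound 1 `COc1cccc(/C=C/c2nc3ccccc3c(=O)[nH]2)c1`: > 25000 nM (limit)
- compound 2 `COc1ccc(/C=C/c2nc3ccccc3c(=O)[nH]2)cc1`: > 25000 nM (limit)
- compound 3 `CCOc1ccc(/C=C/c2nc3ccccc3c(=O)[nH]2)cc1`: > 25000 nM (limit)

Within the data shown here, none of these three entries is a number, and the series so far consists of the limit of > 25000 nM in this assay, at which 3 of the 3 values shown sit, and nothing else. Compound 3 has only the limit > 25000 nM and so has no exact place on the scale.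

The next compound is compound 4 `CCCCOc1ccc(/C=C/c2nc3ccccc3c(=O)[nH]2)cc1`, which keeps the shared core and carries butoxy where compound 3 carries ethoxy. The change is ethyl in place of hydrogen on a saturated chain carbon, two bonds along the chain from an oxygen on an aromatic ring and it sits on a saturated chain carbon, two bonds along the chain from an oxygen on an aromatic ring.

Among the measured compounds shown here, one measured step bears on it, the move from methoxy to ethoxy on the same oxygen. That is a step that the two limits leave unreadable from compound 2 to compound 3 and gives no size to carry forward. For the measured compounds named here, no step of known size therefore supports a shift in either direction in this assay. The working expectation is that compound 4 also reports only a limit. The expected change is a number no higher from compound 3 to compound 4 (the limit leaves the size open) and no direction beyond the scatter is expected. Should a number appear, for compound 4 the estimated value is 25000 nM with an expected range from 10000 nM to 50000 nM in this assay.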

Compound 4, half-maximal inhibitory concentration: > 25000 nM
Compound 4 ended at the assay's limit; the forecaster's own chance of this, stated with the estimate: 85%; the middle value lies on the limit itself.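

In this assay compound 4 gives > 25000 nM, which is a limit and not a number. No new step can be read from compound 2 or compound 3 to compound 4, and the series stands as follows: the limit of > 25000 nM in this assay, at which 4 of the 4 values shown sit.

The compounds shown leave open how methoxy, ethoxy and butoxy on the shared core compare in this assay.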